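This account rests on a few compounds, and the source may have more. Where it says the series, first, only, none or still open, it means among the compounds named here.

Compound 1 `CC1=CC[C@H]2[C@@H]1CC=C(C)[C@@H](CCC1=C(C)CC[C@@H]3OC(C)(C)[C@@H](O)CC[C@@]13C)C2(C)C`: > 50000 nM
Compound 2 `CC1=CC[C@H]2[C@H](CC[C@]2(C)O)C(C)(C)[C@@H]1CC[C@H]1[C@]2(C)CC[C@H](OC(=O)CCC(=O)O)C(C)(C)O[C@H]2CC[C@@]1(C)O`: > 50000 nM
Compound 3 `CC1=CC[C@H]2[C@@H]1CC=C(C)[C@@H](CC[C@H]1[C@]3(C)CC[C@H](OC(=O)c4ccc(C)cc4)C(C)(C)O[C@H]3CC[C@@]1(C)O)C2(C)C`: > 50000 nM

In a functional assay on MCF7 cells (Homo sapiens) for antiproliferative activity, read by MTT assay, with a stated time of 72 h (a higher number here means a weaker inhibitor, a lower number a stronger inhibitor), compound 1 gives only the assay limit, > 50000 nM. Compound 2 likewise gives only a limit in this assay, > 50000 nM. Compound 3 also returns a limit in this assay, > 50000 nM. Compound 2 thus stands where every measured compound stands, at the limit of > 50000 nM in this assay, at which 3 of the 3 values shown sit, with no number to set it apart from the others.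

Compound 4 `CC1=CC[C@H]2[C@H](CC[C@]2(C)O)C(C)(C)[C@@H]1CC[C@H]1[C@]2(C)CC[C@H](OC(=O)c3ccc(C(F)(F)F)cc3)C(C)(C)O[C@H]2CC[C@@]1(C)O` differs from compound 2 by the change (4-(trifluoromethyl)phenyl in place of 2-carboxyethyl on a carbonyl carbon). Going by the values given here, no measured pair isolates this change, and compound 3 also sits at the limit. The step that the limit leaves unreadable from compound 2 to compound 4 is expected to be none beyond the scatter, most likely another limit. For compound 4 the estimate is 60000 nM, with a range of 25000 nM to 150000 nM.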

Compound 4, half-maximal inhibitory concentration: 23400 nM
For compound 4 the middle estimate is 2.6-fold (0.41 log units) above the measured one, and the stated range ends above it.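

On this carbonyl carbon, the ester group changes the read-out in this assay: 4-(trifluoromethyl)phenyl in place of 2-carboxyethyl gives an at least 2.1-fold lower number from compound 2 to compound 4 (0.32 log units; beyond the scatter). Among the compounds shown, only compound 4 gives a number, 23400 nM. The step is only a lower bound, as compound 2 gives a limit: the limit of > 50000 nM in this assay, at which 3 of the 4 values shown sit.

The compounds shown do not separate the contribution of the trifluoromethyl group from that of the aromatic ring, or from the loss of the 2-carboxyethyl group. On these data alone, how an amine or a longer chain on this carbonyl carbon would read in this assay stays open.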